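From pyridin-3-yl to 3-chloropropyl

A few compounds are considered here, and "the series" means these few. Any claim that something is new, unique, unknown or untested is made for them only; others in the source may bear on it.

Measured so far in a functional assay on HeLa cells (Homo sapiens) for antiproliferative activity, read by sulforhodamine B assay, with a stated time of 48 h; a lower number here means a stronger inhibitor of growth, a higher number a weaker inhibitor of growth:
compound 1 `Cc1ccc(-c2cn(CCCN3C(=O)COc4ccccc43)nn2)cc1` gives 14300 nM
compound 2 `O=C1COc2ccccc2N1CCCn1cc(-c2cccnc2)nn1` gives > 100000 nM

Compound 2 stands at > 100000 nM in this assay, which is a limit and not a number. Compound 3 `O=C1COc2ccccc2N1CCCn1cc(CCCCl)nn1` brings the change (3-chloropropyl in place of pyridin-3-yl on an aromatic carbon), with 3-chloropropyl in place of pyridin-3-yl on an aromatic carbon. Within the data shown here, the one measured step at that carbon is an at least 6.9-fold higher number from compound 1 to compound 2 (0.84 log units; beyond the scatter), and it put the pyridin-3-yl there. Compound 1, without the pyridin-3-yl, gives 14300 nM in this assay, so a modest move to a lower number is expected once that group leaves. The expected step is an at least 2.2-fold lower number from compound 2 to compound 3 (0.34 log units; beyond the scatter). For compound 3 the estimated value is 45000 nM, with an expected range of 12000 nM to 100000 nM.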

Compound 3, concentration for 50% growth inhibition: 100 nM
Compound 3: middle estimate off by 450-fold (2.65 log units), on the high side, outside the stated range (below it).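

In this assay, among these compounds, the earlier compounds carried only a ring at this aromatic carbon, and 3-chloropropyl, which has no ring, brings an at least 1000-fold lower number from compound 2 to compound 3 (3.00 log units; beyond the scatter) and a 140-fold lower number from compound 1 to compound 3 (2.16 log units; beyond the scatter). So a ring at this carbon is not needed for strong growth inhibition among these compounds. The first step is only a minimum because compound 2 stands at a limit and not a number: the limit of > 100000 nM in this assay, at which 1 of the 3 values shown sits.

The compounds shown leave open whether the chlorine or the chain itself matters. A plain propyl, an amine at the chain end or a longer chain would help separate the two.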